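Swapping the Dichlorobenzyl Arm for a Methoxybenzyl Arm

The source may hold more compounds than are shown below. What is called first, only, known or untested is meant among the compounds shown, and "the series" means these compounds.

Compound 1 `Nc1cc(N)c2nc(-c3ccccc3)c(NCc3ccc(Cl)c(Cl)c3)nc2c1` was tested in a functional assay on EKVX cells (Homo sapiens) for inhibition, read by sulforhodamine B assay, with a stated time of 48 h (a lower number here means a stronger inhibitor of growth, a higher number a weaker inhibitor of growth), and gave 11000 nM. Within the data shown here, of the two compounds measured so far, compound 1 stands with the highest number; its only companion, compound 2 `COc1cc(CNc2nc3cc(N)cc(N)c3nc2-c2ccccc2)cc(OC)c1OC`, gives 1950 nM in this assay, a gap that lies beyond the usual scatter. Compound 3 `COc1ccc(CNc2nc3cc(N)cc(N)c3nc2-c2ccccc2)cc1` has not yet been measured. It differs from compound 1 in one place: 4-methoxyphenyl in place of 3,4-dichlorophenyl on a saturated chain carbon bound to a nitrogen on an aromatic ring. Among the measured compounds shown here, no pair of measured compounds differs in a single place, so the size of such a step cannot be read directly from the data. The step is expected to be a 2.4-fold lower number from compound 1 to compound 3 (0.39 log units; beyond the scatter), a fall rather than a rise, because compound 2 gives 1950 nM. Compound 3 is therefore estimated to give 4500 nM in this assay, with a range from 1500 nM to 12000 nM.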

Compound 3, concentration for 50% growth inhibition: 14800 nM
The estimate for compound 3 lay 3.3-fold (0.52 log units) below the measured number; measured number above the stated range.
By their numbers in this assay, from the lowest: compound 2; then compounds 1 and 3 (each within the scatter of the next).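

In this assay, among these compounds, the one change at this place can now be read directly (step: a 1.3-fold higher number from compound 1 to compound 3 (0.13 log units; within the scatter)). On a saturated chain carbon bound to a nitrogen on an aromatic ring, 3,4-dichlorophenyl and 4-methoxyphenyl give numbers within the scatter of each other, so on this core this exchange of the two chlorines for one methoxy group does not separate the compounds. Nothing at hand accounts for this result.

On these data alone, it remains open whether the further methoxy groups on the arm of compound 2 are tied to its number of 1950 nM, a question that its printed value alone cannot settle. Also open, as far as these compounds go, is how this position would respond to a different arm, such as a 4-hydroxyphenyl group, a pyridine ring, or a longer chain.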